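This account rests on a few compounds, and the source may have more. Where it says the series, first, only, none or still open, it means among the compounds named here.

Compound 2 `Cc1cccc(Cc2nc(N)c3nn(-c4ccccc4)cc3n2)c1` holds the highest number of the three measured compounds in an assay on CHO cells for displacement of a labelled ligand from adenosine receptor A1 (Homo sapiens), read by scintillation counting, tested at 1 uM (a lower number here means less inhibition, a higher number more inhibition at the concentration tested (going by the name of the read-out)), where compound 2 gives 41%. Compound 3 `Cc1ccc(Cc2nc(N)c3nn(-c4ccccc4)cc3n2)cc1` lies within the scatter of it, as compound 3 gives 38%, while compound 1 `CC(C)c1nc(N)c2nn(-c3ccccc3)cc2n1` stands far lower, as compound 1 gives 2%. Compound 4 `Nc1nc(Cc2cccc(Cl)c2)nc2cn(-c3ccccc3)nc12` differs from compound 2 in one place: chloro in place of methyl on an aromatic carbon. The step of a number 3 percentage points lower from compound 2 to compound 3 (within the scatter) shows that 4-methylbenzyl in place of 3-methylbenzyl changed little, whereas the large steps of a number 39 percentage points higher from compound 1 to compound 2 (beyond the scatter) and a number 36 percentage points higher from compound 1 to compound 3 (beyond the scatter) separate the isopropyl compound from both benzyl compounds. Within the data shown here, no measured step swaps methyl for chloro, so a step of about zero is expected: a number 1 percentage points lower from compound 2 to compound 4 (within the scatter). Compound 4 is therefore estimated at 40%, in a range from 20% to 60%.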

Compound 4, a percentage reported as inhibition, at one concentration (the size of the read-out at that concentration, not a potency): 32%
Compound 4: middle estimate off by 8 percentage points, on the high side, within the range that was stated.
By their numbers in this assay, from the lowest: compound 1; then compounds 4, 3 and 2 (each within the scatter of the next).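

At this place, on an aromatic carbon meta to a large group, chloro reads much like methyl in this assay with a number 9 percentage points lower from compound 2 to compound 4 (within the scatter) and the 3-chlorobenzyl group reads much like the 4-methylbenzyl group with a number 6 percentage points lower from compound 3 to compound 4 (within the scatter) as well. The gain over isopropyl therefore does not need a methyl group on the benzyl, as a number 30 percentage points higher from compound 1 to compound 4 (beyond the scatter) shows. No evidence at hand accounts for these steps. Still open, going by these compounds, is how a methoxy group, an amine or a carboxylic acid would read in place of chloro.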